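A Benzyloxy Group in a Series at Its Limit

The compounds below may be only part of what the source reports. "The series", "measured", "known", "first", "only" and "open" are said of these compounds alone.

Values measured in an ADME assay on HepG2 cells (Homo sapiens) for cytotoxicity, read by MTT assay, with a stated time of 48 h (a lower number here means a stronger inhibitor, a higher number a weaker inhibitor), are as follows.
- Compound 1 `Cc1ccc(Nc2ncnc3ccc(-c4ccc(S(=O)(=O)N5CCOCC5)cc4)cc23)cc1` gives > 15000 nM, which is a limit.
- Compound 2 `O=S(=O)(c1ccc(-c2ccc3ncnc(Nc4ccc(O)c(Cl)c4)c3c2)cc1)N1CCOCC1` gives > 15000 nM, which is a limit.
- Compound 3 `COc1ccc(Nc2ncnc3ccc(-c4ccc(S(=O)(=O)N5CCOCC5)cc4)cc23)cc1Cl` gives > 15000 nM, which is a limit.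

Compound 3 has no numerical value in this assay and stands at > 15000 nM, a limit and not a number. The same holds for the other two measured compounds, and the series offers only (the limit of > 15000 nM in this assay, at which 3 of the 3 values shown sit).

Compound 4 `O=S(=O)(c1ccc(-c2ccc3ncnc(Nc4ccc(OCc5ccccc5)c(Cl)c4)c3c2)cc1)N1CCOCC1` extends the methoxy of compound 3 to benzyloxy. The change is phenyl in place of hydrogen on a saturated chain carbon bound to an oxygen on an aromatic ring, with phenyl in place of hydrogen on a saturated chain carbon bound to an oxygen on an aromatic ring.

The closest measured change is at the same oxygen, a step that the two limits leave unreadable from compound 2 to compound 3. The two changes on the nitrogen-bound aryl group are a step that the two limits leave unreadable from compound 1 to compound 2 and a step that the two limits leave unreadable from compound 1 to compound 3. None of these gives a size to carry over, but none of the three compounds reached a number in this assay. For the measured compounds named here, no step of definite size or direction is therefore expected, and compound 4 is expected to remain close to the limit, quite possibly reported only as a limit.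

The expected change is a step that the limit leaves unreadable from compound 3 to compound 4.

For compound 4 the estimated value is 16000 nM, with an expected range from 7000 nM to 30000 nM.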

Compound 4, half-maximal inhibitory concentration: > 15000 nM
Compound 4: no number, only a limit; the forecaster's own chance of this, stated with the estimate: 65%; the middle value is on the limit's open side.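

In this assay compound 4 gives > 15000 nM which is a limit and not a number. For the compounds shown here, compound 2 and compound 3 also stand at a limit, so no step to compound 4 can be read. The compounds shown leave open whether any change on the nitrogen-bound aryl group alters the value at all, and the series offers only this: the limit of > 15000 nM in this assay, at which 4 of the 4 values shown sit.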